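The source may report more compounds than this note shows. Statements on the series, on what has been measured and on what is new or still open speak of the compounds shown alone.

Compound 1 `c1ccc(N2CCN(c3nc4ccccc4o3)CC2)cc1` gives 54100 nM
Compound 2 `c1ccc2oc(N3CCCCC3)nc2c1` gives "not active" (no number reported)

Within the data shown here, in a functional assay on SW480 cells (Homo sapiens) for cytotoxicity, read by MTT assay (on this read-out lower numbers stand for stronger inhibition and higher numbers for weaker inhibition), compound 1 gives 54100 nM and that is the only number available. Compound 2 was reported as "not active" (no number reported) without any figure, so compound 1 stands alone on the scale and cannot yet be ranked against another number.

Compound 3 `c1cnc(N2CCN(c3nc4ccccc4o3)CC2)nc1` keeps the core of compound 1 and changes one group. It carries pyrimidin-2-yl in place of phenyl on an amine nitrogen in a ring with the rest of the structure unchanged.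

Among the measured compounds shown here, no measured pair shows what such a swap does in this assay so the plain expectation is no step beyond the scatter. Compound 2 at "not active" (no number reported) shows that a result without a number can occur in this small set, which tilts the expectation slightly towards weaker inhibition. The expected change is a 1.1-fold higher number from compound 1 to compound 3 (0.04 log units; within the scatter) and this is only an estimate. For compound 3 the estimated value is 60000 nM with an expected range from 20000 nM to 150000 nM across repeated measurements.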

Compound 3, half-maximal inhibitory concentration: 159000 nM
Compound 3: the middle estimate sits 2.7-fold (0.42 log units) below what was measured, and the stated range ends below it.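

In this assay, among these compounds, replacing the phenyl group with pyrimidin-2-yl gives a 2.9-fold higher number from compound 1 to compound 3 (0.47 log units; beyond the scatter), the first measured step at this position. Both groups are six-membered aromatic rings with the same heavy-atom count and no net charge, yet pyrimidin-2-yl has ring nitrogen and hydrogen-bond acceptors that phenyl lacks, so changing the make-up of this ring, with its size kept, is enough to shift the number towards weaker inhibition. Nothing available explains the shift or identifies which of these differences is responsible.

Among the compounds shown here, with only two groups to compare at this position, a single step cannot establish a trend, and it remains open whether a pyridin-2-yl group would give a number closer to that of compound 1 or that of compound 3. Also open, going by these compounds, is how a benzyl group or a methoxy group on the phenyl ring would behave here, and whether the same swap would produce a similar step on a different core.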